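Extending a Methyl to Ethyl on the Shared Core

The compounds below may be only part of what the source reports. "The series", "measured", "known", "first", "only" and "open" are said of these compounds alone.

In a functional assay on Jurkat cells for inhibition of nuclear factor NF-kappa-B complex (Homo sapiens) (on this read-out lower numbers stand for stronger inhibition and higher numbers for weaker inhibition), compound 2 `CCOC(=O)c1cnc(C)nc1NN1C(=O)C=C(C)C1=O` gives 16000 nM, the higher of the two numbers measured here; compound 1 `CCOC(=O)c1cnc(C(F)(F)F)nc1NN1C(=O)C=C(C)C1=O` gives 1000 nM. For the measured compounds named here, the single measured step, a 16-fold higher number from compound 1 to compound 2 (1.20 log units; beyond the scatter), concerns a different change on the same aromatic carbon. Compound 3 `CCOC(=O)c1cnc(CC)nc1NN1C(=O)C=C(C)C1=O` differs from compound 2 by methyl in place of hydrogen on a saturated chain carbon bound to an aromatic carbon, read one bond further out as methyl to ethyl. Going by the values given here, no measured step bears on this change, so only a small shift is expected for compound 3, a 1.1-fold lower number from compound 2 to compound 3 (0.06 log units; within the scatter). Compound 3 is therefore estimated at 14000 nM, with a range from 4000 nM to 50000 nM.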

Compound 3, half-maximal inhibitory concentration: 10000 nM
Compound 3: the middle estimate sits 1.4-fold (0.15 log units) above what was measured, and the stated range covers the measured number.
By their numbers in this assay, from the lowest: compound 1; then compounds 3 and 2 (each within the scatter of the next).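

Lengthening methyl to ethyl on this aromatic carbon gives a step in this assay that stays within the usual scatter (a 1.6-fold lower number from compound 2 to compound 3 (0.20 log units; within the scatter)), so the two chains cannot be told apart here. Trifluoromethyl stands clear of ethyl as well (a 10-fold higher number from compound 1 to compound 3 (1.00 log units; beyond the scatter)), so among the three groups shown, only trifluoromethyl stands apart. Nothing measured here explains this. From the compounds shown here alone, whether a longer chain such as propyl, or an amine, on this carbon would read like trifluoromethyl or like methyl and ethyl stays open.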